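Moving the Nitro Group Around the Thiourea Aryl Ring

This account rests on a few compounds, and the source may have more. Where it says the series, first, only, none or still open, it means among the compounds named here.

Going by the values given here, compound 3 `O=[N+]([O-])c1cccc(NC(=S)NCCNS(=O)(=O)c2ccc(-c3ccccc3OCc3ccccc3)s2)c1` gives 11600 nM in a functional assay on RS4-11 cells (Homo sapiens) for inhibition, read by CCK-8 assay, with a stated time of 48 h (a lower number here means a stronger inhibitor, a higher number a weaker inhibitor), one of only two actual numbers recorded here; the other belongs to compound 1 `O=[N+]([O-])c1ccc(NC(=S)NCCNS(=O)(=O)c2ccc(-c3ccccc3O[C@H]3CC[C@@H](O)CC3)s2)cc1`, which gives 9400 nM in this assay, a value within the usual scatter of that of compound 3. Compound 2 `O=S(=O)(NCCNC(=S)Nc1ccc(Cl)cc1)c1ccc(-c2ccccc2OCc2ccccc2)s1` reaches only the assay limit > 50000 nM in this assay. Among the compounds with values here, the single measured step, an at least 4.3-fold lower number from compound 2 to compound 3 (0.63 log units; beyond the scatter), starts from that limit (the limit of > 50000 nM in this assay, at which 1 of the 3 values shown sits). Compound 4 `O=[N+]([O-])c1ccc(NC(=S)NCCNS(=O)(=O)c2ccc(-c3ccccc3OCc3ccccc3)s2)cc1` differs from compound 3 by 4-nitrophenyl in place of 3-nitrophenyl on an amide-type nitrogen. Within the data shown here, no measured step swaps these two nitrophenyl groups, yet compound 1 already carries 4-nitrophenyl and sits within the scatter of compound 3, so little change is expected. The expected step is a 1.3-fold lower number from compound 3 to compound 4 (0.11 log units; within the scatter). Compound 4 is therefore estimated at 9000 nM in this assay, with a range from 3500 nM to 25000 nM.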

Compound 4, half-maximal inhibitory concentration: 11300 nM
Estimate against measurement, compound 4: 1.3-fold (0.10 log units) below; the range from low to high includes it.
By their numbers in this assay, from the lowest: compounds 1, 4 and 3 (each within the scatter of the next). At a limit, above all of these: compound 2.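

In this assay, 4-nitrophenyl in place of 3-nitrophenyl on the amide-type nitrogen gives a 1.0-fold lower number from compound 3 to compound 4 (0.01 log units; within the scatter), so moving the nitro group between these two places changes nothing that can be detected. Nitro in place of chloro gives an at least 4.4-fold lower number from compound 2 to compound 4 (0.64 log units; beyond the scatter), a step read from the limit of compound 2: the limit of > 50000 nM in this assay, at which 1 of the 4 values shown sits. Benzyl in place of 4-hydroxycyclohexyl on the oxygen gives a 1.2-fold higher number from compound 1 to compound 4 (0.08 log units; within the scatter), so this assay does not separate those two groups. Going by these compounds, whether a nitrile or a trifluoromethyl group on that aromatic carbon would serve as well as nitro remains open.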